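This account rests on a few compounds, and the source may have more. Where it says the series, first, only, none or still open, it means among the compounds named here.

Going by the values given here, in an ADME assay on RAW264.7 cells (Mus musculus) for cytotoxicity, read by trypan blue exclusion, with a stated time of 48 h (on this read-out lower numbers stand for stronger inhibition of growth and higher numbers for weaker inhibition of growth), compound 3, `Cc1cc(CNC2CCCCC2)c(C)n1-c1ccc(Cl)cc1`, gives 10 ug/mL, the lowest of the three numbers measured so far. Compound 2, `Cc1cc(CNCc2ccc(F)cc2)c(C)n1-c1ccc(Cl)cc1`, gives 26 ug/mL, and compound 1, `Cc1cc(/C=N\OCc2ccccc2)c(C)n1-c1ccc(Cl)cc1`, gives 128 ug/mL, so compound 3 sits at the growth-inhibiting end of this small set.

The next compound to test is compound 4, `Cc1cc(CNCc2ccccc2)c(C)n1-c1ccc(Cl)cc1`, which has benzyl in place of cyclohexyl on an amine nitrogen.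

Among the compounds with values here, only one measured step changes the same place, and it is a 2.6-fold lower number from compound 2 to compound 3 (0.41 log units; beyond the scatter). That modest step put cyclohexyl in place of 4-fluorobenzyl. The change to compound 4 runs the other way, from cyclohexyl back to a benzyl group that lacks only the fluoro of 4-fluorobenzyl. Compound 1 is not linked to the others by any single-place step, so it offers little guidance here.

A higher number in this assay is therefore expected, meaning weaker inhibition of growth, by about the size of that one step. With a single step as the guide, this expectation remains uncertain. The expected change is a 2.5-fold higher number from compound 3 to compound 4 (0.40 log units; beyond the scatter). For compound 4 the estimated value is 25 ug/mL, with an expected range from 12 ug/mL to 52 ug/mL.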

Compound 4, concentration for 50% growth inhibition: 5.5 ug/mL
The estimate for compound 4 lay 4.5-fold (0.66 log units) above the measured number; measured number below the stated range.
By their numbers in this assay, from the lowest: compounds 4 and 3 (each within the scatter of the next); then compound 2; then compound 1.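

In this assay, the result does not separate the saturated ring from the aromatic ring on this amine nitrogen: benzyl in place of cyclohexyl gives a 1.8-fold lower number from compound 3 to compound 4 (0.26 log units; within the scatter) and so makes no clear difference. The clear change comes instead from a single atom elsewhere in the same side group, as hydrogen in place of fluoro on an aromatic carbon gives a 4.7-fold lower number from compound 2 to compound 4 (0.67 log units; beyond the scatter), so the earlier gap between compound 2 and compound 3 cannot be read as cyclohexyl simply outperforming a benzyl-type group. Nothing in the available data explains why removing the fluoro moves the number this much.

On these data alone, this fluoro effect rests on one pair of compounds, so it remains open whether another group on that aromatic carbon, such as methoxy or a nitrile, would also give a higher number than hydrogen. As far as these compounds go, it is also open whether an open chain on the amine nitrogen, such as hexyl, would match the two rings or fall away from them.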